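The source may report more compounds than this note shows. Statements on the series, on what has been measured and on what is new or still open speak of the compounds shown alone.

Of the compounds shown here, two with a shared core have been measured in an assay on HEK293 cells for displacement of a labelled ligand from NPC1-like intracellular cholesterol transporter 1 (Homo sapiens); a higher number here means a weaker inhibitor, a lower number a stronger inhibitor. Compound 1 `CC(C)(C)OC(=O)NCCNC(=O)CN1CN(c2ccccc2)C2(CCN(C(=O)c3ccc(C(C)(C)C)cc3)CC2)C1=O` gives 10900 nM. Compound 2 `CC(C)(C)OC(=O)NCCCNC(=O)CN1CN(c2ccccc2)C2(CCN(C(=O)c3ccc(C4CCCCC4)cc3)CC2)C1=O` gives 6000 nM. Among these two numbers compound 2 has the lower one, and compound 1 is its only neighbour, with a number that lies within the usual scatter of the measurement, so no ordering between the two can be claimed.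

Compound 3 `O=C(CN1CN(c2ccccc2)C2(CCN(C(=O)c3ccc(C4CCCCC4)cc3)CC2)C1=O)N1CCCCC1` has not yet been measured in this assay. It differs from compound 2 in one place: piperidin-1-yl in place of (3-((tert-butoxycarbonyl)amino)propyl)amino on a carbonyl carbon. Going by the values given here, no measured pair in this set shows the effect of such a change, so there is no measured step to lean on; what remains is the single number of compound 2 in this assay.

Given that lack, compound 3 is expected to land close to compound 2, with no step beyond the scatter in either direction as the most likely outcome. The change from the amide bearing the tert-butoxycarbonylamino propyl chain to the piperidinyl amide is thus estimated to give a step of a 1.2-fold lower number from compound 2 to compound 3 (0.08 log units; within the scatter). Compound 3 is accordingly expected to show about 5000 nM in this assay, within a range from 1500 nM to 20000 nM.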

Compound 3, half-maximal inhibitory concentration: 1100 nM
Compound 3: middle estimate off by 4.5-fold (0.66 log units), on the high side; measured number outside the range, below it.
By their numbers in this assay, from the lowest: compound 3; then compounds 2 and 1 (each within the scatter of the next).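

In this assay, the group on this carbonyl carbon turns out to matter: piperidin-1-yl in place of (3-((tert-butoxycarbonyl)amino)propyl)amino gives a 5.5-fold lower number from compound 2 to compound 3 (0.74 log units; beyond the scatter), a step beyond the scatter and the first in this set to be read from a change in one place. The open chain of 12 heavy atoms, with its 2 hydrogen-bond donors and 2 hydrogen-bond acceptors, is therefore not required for the lower number in this pair, since a six-membered non-aromatic ring of 6 heavy atoms with no donors or acceptors gives a lower number in its place. Nothing available here bears on the reason for this step.

Going by these compounds alone, the single pair cannot separate the loss of the chain's length from the loss of its donors or the arrival of a ring, so an open dialkylamine such as diethylamino, or a ring with a second hetero atom such as morpholin-4-yl, would be needed at this carbonyl carbon to tell these apart. From the compounds shown here alone, it also remains open whether piperidin-1-yl gives a similar step when the cyclohexyl group of compound 3 is replaced by the tert-butyl group of compound 1.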